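Extending an Ethoxy Chain on a Shared Core

The source may hold more compounds than are shown below. What is called first, only, known or untested is meant among the compounds shown, and "the series" means these compounds.

Of the compounds shown here, three built on the same core have been tested in an ADME assay on MT4 cells (Homo sapiens) for cytotoxicity, read by MTT assay, with a stated time of 4 days; on this read-out lower numbers stand for higher toxicity in this test and higher numbers for lower toxicity in this test. Compound 1 `COc1ccccc1Oc1nc(Nc2ccc(C#N)cc2)nc2ccccc12` gives 150000 nM in this assay. Compound 2 `N#Cc1ccc(Nc2nc(Oc3ccc(Cl)cc3Cl)c3ccccc3n2)cc1`, which carries a 2,4-dichlorophenyl in place of the 2-methoxyphenyl on the aromatic oxygen, gives 32000 nM; that change produced a 4.7-fold lower number from compound 1 to compound 2 (0.67 log units; beyond the scatter). Compound 3 `CCOc1cc(C#N)cc(OCC)c1Oc1nc(Nc2ccc(C#N)cc2)nc2ccccc12` gives 108000 nM in this assay, a number that sits close to compound 1, within the scatter, and clearly higher than compound 2, beyond it.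

Compound 4 `CCCOc1cc(C#N)cc(OCC)c1Oc1nc(Nc2ccc(C#N)cc2)nc2ccccc12` differs from compound 3 in one place only: methyl in place of hydrogen on a saturated chain carbon, two bonds along the chain from an oxygen on an aromatic ring. For the measured compounds named here, no measured step concerns this kind of change; the single measured step, from compound 1 to compound 2, swaps one whole aryl group for another at the aromatic oxygen and says nothing about lengthening a chain. Going by the values given here, with no step to lean on, the expectation is that adding one carbon to the chain leaves the result where compound 3 stands, so the step from compound 3 to compound 4 in this assay is expected to be a 1.1-fold lower number from compound 3 to compound 4 (0.03 log units; within the scatter), within the scatter. For compound 4 the estimated value in this assay is 100000 nM, expected to lie between 50000 nM and 200000 nM.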

Compound 4, half-maximal cytotoxic concentration: 123000 nM
Estimate against measurement, compound 4: 1.2-fold (0.09 log units) below, within the range that was stated.
By their numbers in this assay, from the lowest: compound 2; then compounds 3, 4 and 1 (each within the scatter of the next).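

In this assay, the change from ethoxy to propoxy, which puts methyl in place of hydrogen on a saturated chain carbon, two bonds along the chain from an oxygen on an aromatic ring, gives a 1.1-fold higher number from compound 3 to compound 4 (0.06 log units; within the scatter). For the compounds shown here, this is the first measured step that alters a chain rather than swapping a whole aryl group, and it shows that adding this single carbon leaves no readable difference in this test, since the step lies within the usual scatter of repeated measurements. Nothing measured here offers a reason for this outcome.

From the compounds shown here alone, what would happen with a butoxy chain, or with a chain ending in an amine or a carboxylic acid, remains open, as does whether such groups would stay within the scatter of compound 3 in this assay. A single step of one carbon also cannot establish a trend with chain length, so the flat result holds only for the ethoxy to propoxy change between these two compounds.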